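Working notes: methoxy to ethoxy on compound 1

The compounds below may be only part of what the source reports. "The series", "measured", "known", "first", "only" and "open" are said of these compounds alone.

Measured in a functional assay on NCI-H1975 cells (Homo sapiens) for antiproliferative activity, read by MTT assay, with a stated time of 72 h; a higher number here means a weaker inhibitor, a lower number a stronger inhibitor:
- compound 1 `COc1ccc(Nc2cc(NC(=O)c3ccccc3)ncn2)cc1`: 11400 nM
- compound 2 `O=C(Nc1cc(Nc2ccc(Cl)cc2)ncn1)c1ccc(F)cc1`: 17600 nM

The two measured numbers lie within the scatter of each other, so compound 1 has the lower number on paper but cannot be ranked against compound 2. Among the measured compounds shown here, no step between measured compounds that differ in one place is available, which leaves the size of any single change unmeasured.

The next compound for this assay is compound 3 `CCOc1ccc(Nc2cc(NC(=O)c3ccccc3)ncn2)cc1`. It departs from compound 1 by methyl in place of hydrogen on a saturated chain carbon bound to an oxygen on an aromatic ring. In words, this is methyl in place of hydrogen on a saturated chain carbon bound to an oxygen on an aromatic ring, or methoxy to ethoxy.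

For the measured compounds named here, with no measured step to draw on, no shift beyond the scatter is expected, and no direction is predicted. Going by the values given here, the starting point is compound 1 at 11400 nM, and the range is kept wide because only two values are known. The estimated step is a 1.0-fold lower number from compound 1 to compound 3 (0.02 log units; within the scatter). For compound 3 the expected value is 11000 nM, with an estimated range of 5000 nM to 24000 nM.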

Compound 3, half-maximal inhibitory concentration: 7070 nM
Beside the measured number, compound 3's estimate is 1.6-fold (0.19 log units) above it; low and high end bracket the measured number.
By their numbers in this assay, from the lowest: compounds 3, 1 and 2 (each within the scatter of the next, the first and the last beyond it).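

The methoxy to ethoxy change gives this series its first measured step in one place: in this assay, the step is a 1.6-fold lower number from compound 1 to compound 3 (0.21 log units; within the scatter) and so does not separate the two compounds. At this position, on a saturated chain carbon bound to an oxygen on an aromatic ring, methyl in place of hydrogen is therefore tolerated without a shift beyond the scatter, which compounds 1 and 2 alone could not show. This single step gives a first measure of how much the number moves for one added carbon here, but no measurement on hand offers an explanation for it.

As far as these compounds go, whether a longer chain such as propoxy, a branched isopropoxy group or a terminal amine on the chain would move the number beyond the scatter remains open. Also open, from the compounds shown here alone, is whether methyl in place of hydrogen at this position would give a similar step with a different group on the benzamide ring, such as the fluorine carried by compound 2.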